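Working notes on the ketone-side aryl group in this series

The source may hold more compounds than are shown below. What is called first, only, known or untested is meant among the compounds shown, and "the series" means these compounds.

Compound 1, `COc1ccc(OC)c(C(=O)/C=C/c2cn(-c3ccccc3)nc2-c2ccsc2)c1`, gives 3400 nM in a functional assay on HCT-116 cells (Homo sapiens) for inhibition, read by sulforhodamine B assay, with a stated time of 72 h; a lower number here means a stronger inhibitor, a higher number a weaker inhibitor. Compound 2, `COc1ccc(C(=O)/C=C/c2cn(-c3ccccc3)nc2-c2ccsc2)c(OC)c1`, gives 2200 nM in this assay. Compound 3, `O=C(/C=C/c1cn(-c2ccccc2)nc1-c1cccnc1)c1ccsc1`, gives 1300 nM in this assay.

Compound 3 has the lowest number of the three. Its gap to compound 2 is within the scatter, so the two cannot be ordered; its gap to compound 1 is beyond the scatter, so compound 3 is the stronger inhibitor of that pair. Within the data shown here, the only single-point step among the measured compounds, a 1.5-fold lower number from compound 1 to compound 2 (0.19 log units; within the scatter), concerns the group on the carbonyl carbon and is itself within the scatter.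

Compound 4, `O=C(/C=C/c1cn(-c2ccccc2)nc1-c1cccnc1)c1ccccn1`, differs from compound 3 by pyridin-2-yl in place of thiophen-3-yl on a carbonyl carbon. Among the measured compounds shown here, no measured pair shows a change from a five-membered to a six-membered ring at this position, so the step from compound 1 to compound 2 is the only guide, and it moved the number very little. Compound 4 is therefore expected to lie close to compound 3 in this assay, with the expected step of a 1.2-fold higher number from compound 3 to compound 4 (0.06 log units; within the scatter) not beyond the scatter. The estimate for compound 4 is 1500 nM, within a range of 500 nM to 4500 nM.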

Compound 4, half-maximal inhibitory concentration: 2100 nM
Compound 4: the middle estimate sits 1.4-fold (0.15 log units) below what was measured, and the stated range covers the measured number.
By their numbers in this assay, from the lowest: compounds 3, 4, 2 and 1 (each within the scatter of the next, the first and the last beyond it).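

Among these compounds, replacing thiophen-3-yl with pyridin-2-yl on a carbonyl carbon is the first measured exchange of a five-membered for a six-membered aromatic ring at this position, and in this assay it gives a 1.6-fold higher number from compound 3 to compound 4 (0.21 log units; within the scatter), so compound 3 and compound 4 cannot be ordered. On the core shared by this pair, ring size and the identity of the hetero atom can therefore change together, sulfur giving way to nitrogen, without a step beyond the scatter; this holds for this one exchange only, and it cannot be divided between the two changes. No measurement on hand offers an explanation for the small step seen here.

On these data alone, how an aryl group carrying an amine, a carboxylic acid or a longer alkyl chain on the carbonyl carbon would read in this assay remains open, since both groups in this pair are unsubstituted aromatic rings with a single hetero atom. Also open, as far as these compounds go, is how the 2,4-dimethoxyphenyl and 2,5-dimethoxyphenyl groups would read on the core of compound 3, as compound 1 and compound 2 differ from it in more than one place.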